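Swapping a Piperidine for a Dimethylmorpholine on a Kinase Inhibitor

A few compounds are considered here, and "the series" means these few. Any claim that something is new, unique, unknown or untested is made for them only; others in the source may bear on it.

Compound 1 `O=C(Nc1ccnnc1)c1cc(N2CCCCC2)ccc1OCc1ccccc1` was tested in an assay on Sf9 cells for inhibition of Leucine-rich repeat serine/threonine-protein kinase 2 (Homo sapiens), read by TR-FRET, with stated times of 30 min and 2 h (a higher number here means a weaker inhibitor, a lower number a stronger inhibitor), where compound 1 gives 25.1 nM. Two relatives were measured alongside it: compound 2 `O=C(Nc1cccc(Cl)c1)c1cc(C(F)(F)F)ccc1OCc1ccc(F)cc1` gives 12.6 nM, and compound 3 `O=C(Nc1cccnc1)c1cc(C(F)(F)F)ccc1OCc1ccccc1` gives 12.6 nM. Both numbers lie within the usual scatter of the number for compound 1, so the three compounds cannot be told apart on potency. Compound 4 `C[C@@H]1CN(c2ccc(OCc3ccccc3)c(C(=O)Nc3ccnnc3)c2)C[C@H](C)O1` has not yet been measured. It differs from compound 1 in one place: 2,6-dimethylmorpholin-4-yl in place of piperidin-1-yl on an aromatic carbon. Going by the values given here, no measured pair shows what this exchange does, so the expectation rests on the structural change alone. In this assay the expected step is a 1.3-fold lower number from compound 1 to compound 4 (0.10 log units; within the scatter), no larger than the scatter. Compound 4 is estimated at 20 nM, with a range from 6 nM to 70 nM.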

Compound 4, half-maximal inhibitory concentration: 20 nM
Estimate against measurement, compound 4: no gap at the digits printed, and the stated range covers the measured number.
By their numbers in this assay, from the lowest: compounds 2, 3, 4 and 1 (each within the scatter of the next).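

At this position, para to a benzyloxy group, the core of compound 1 accepts a bigger group with a ring oxygen and two defined stereocentres. In this assay the exchange of piperidin-1-yl for 2,6-dimethylmorpholin-4-yl gives a 1.3-fold lower number from compound 1 to compound 4 (0.10 log units; within the scatter) and so leaves potency unchanged as far as can be read. Nothing measured here explains why the two groups match.

As far as these compounds go, whether a carboxylic acid or a primary amine at this place would keep the number in the same range remains open. The same holds for a longer chain such as an ethoxyethyl ether.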